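The source may hold more compounds than are shown below. What is called first, only, known or untested is meant among the compounds shown, and "the series" means these compounds.

Values in an ADME assay on THP-1 cells (Homo sapiens) for cytotoxicity; on this read-out higher numbers stand for lower toxicity in this test and lower numbers for higher toxicity in this test:
Compound 1 `Cc1ccc([C@@H]2C[C@H](O)Cc3ccccc3N2)s1`: 608000 nM
Compound 2 `Cc1ccc([C@@H]2C[C@H](O)Cc3cc(Cl)ccc3N2)s1`: > 2040000 nM, which is a limit of the assay
Compound 3 `O[C@@H]1Cc2cc(F)ccc2N[C@H](c2cccs2)C1`: 190000 nM

Compound 3 stands lowest of the two numbers, with compound 1 the nearest. The remaining value, that of compound 2, is a limit (the limit of > 2040000 nM in this assay, at which 1 of the 3 values shown sits). Compound 4 `Cc1ccc([C@@H]2C[C@H](O)Cc3cc(F)ccc3N2)s1` differs from compound 3 by methyl in place of hydrogen on an aromatic carbon. Among the measured compounds shown here, no measured step covers this change: the single step of an at least 3.3-fold higher number from compound 1 to compound 2 (0.52 log units; beyond the scatter) concerns chloro in place of hydrogen on the other ring, and compounds 1 and 3 differ in two places, so their two values show only that compound 1 sits higher than compound 3 in this assay. Compound 4 is therefore expected to shift by a 1.8-fold higher number from compound 3 to compound 4 (0.27 log units; within the scatter). The upward lean rests on the methyl-bearing compound 1, which gives 608000 nM. The estimate for compound 4 is 350000 nM, range 120000 nM to 1000000 nM.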

Compound 4, half-maximal cytotoxic concentration: 312000 nM
For compound 4 the middle estimate is 1.1-fold (0.05 log units) above the measured one; the measured number falls inside the stated range.
By their numbers in this assay, from the lowest: compounds 3, 4 and 1 (each within the scatter of the next, the first and the last beyond it). At a limit, above all of these: compound 2.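

The methyl next to the ring sulfur now has a direct reading in this assay (a 1.6-fold higher number from compound 3 to compound 4 (0.22 log units; within the scatter)), and compounds 3 and 4 cannot be told apart. With 5-methylthiophen-2-yl in place, fluoro in place of hydrogen also stays inside the scatter (a 1.9-fold lower number from compound 1 to compound 4 (0.29 log units; within the scatter)), while fluoro in place of chloro does not (an at least 6.5-fold lower number from compound 2 to compound 4 (0.81 log units; beyond the scatter)). Compound 2 stands at a limit of the assay: the limit of > 2040000 nM in this assay, at which 1 of the 4 values shown sits.

From the compounds shown here alone, whether an ethyl or an aminomethyl group in this place would separate from compound 3 stays open. Also open, going by these compounds, is whether chloro gives a comparable step with thiophen-2-yl.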